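This account rests on a few compounds, and the source may have more. Where it says the series, first, only, none or still open, it means among the compounds named here.

Measured compounds in an assay (Cavia porcellus) for inhibition of Polyunsaturated fatty acid 5-lipoxygenase (Homo sapiens); a higher number here means a weaker inhibitor, a lower number a stronger inhibitor:
Compound 1, `CN(O)C(=O)C1=Cc2ccccc2OC1`: compound 1 gives 180 nM.
Compound 2, `NC(=O)N(O)CC1=Cc2cc(OCc3ccc(C(F)(F)F)cc3)ccc2OC1`: compound 2 gives 490 nM.
Compound 3, `CCCCCCOc1ccc2c(c1)C=C(CN(O)C(N)=O)CO2`: compound 3 gives 340 nM.

Compound 3 stands second highest of the three numbers in this assay. Its nearest neighbour is compound 2, whose number is higher but within the usual scatter, and its furthest is compound 1, whose number is lower, yet also within the scatter. The three measured values therefore do not separate from one another, and no order among them can be claimed.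

Compound 4, `NC(=O)N(O)CC1=Cc2cc(OCCCc3ccccc3)ccc2OC1`, has not yet been measured in this assay. The change from compound 3 to compound 4 is phenyl in place of propyl on a saturated chain carbon, three bonds along the chain from an oxygen on an aromatic ring. Going by the values given here, no step between two measured compounds isolates this change, so its effect is not known from the data. Among the compounds with values here, the only hint is that compound 2, whose structure also contains a second aromatic ring, gives 490 nM, a value within the scatter of compound 3.

Compound 4 is therefore expected to show no step beyond the scatter, the estimated step from compound 3 to compound 4 being a 1.0-fold higher number from compound 3 to compound 4 (0.01 log units; within the scatter). The value for compound 4 in this assay is estimated at 350 nM, within a range from 120 nM to 1000 nM.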

Compound 4, half-maximal inhibitory concentration: 160 nM
Compound 4: the middle estimate sits 2.2-fold (0.34 log units) above what was measured; the measured number falls inside the stated range.
By their numbers in this assay, from the lowest: compounds 4, 1, 3 and 2 (each within the scatter of the next, the first and the last beyond it).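

In this assay, phenyl in place of propyl on a saturated chain carbon, three bonds along the chain from an oxygen on an aromatic ring, gives a 2.1-fold lower number from compound 3 to compound 4 (0.33 log units; beyond the scatter), a modest step and the first in this set to isolate a single change. It shows that this end of the chain is not indifferent to what it carries: a six-membered aromatic ring of carbon only, with six heavy atoms in place of three, goes with a stronger inhibitor than the open propyl end does. Nothing in the data gives a reason for this step.

Going by these compounds alone, the single step changes two things at once, the number of heavy atoms and the presence of an aromatic ring, so it cannot say which of them goes with the lower number. A cyclohexyl group at this place would bear on that question, while a longer chain, or an amine or a carboxylic acid on the new phenyl, leaves open how far the trend extends.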